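Swapping an Amine for an Azide on a Nucleoside Core

The source may report more compounds than this note shows. Statements on the series, on what has been measured and on what is new or still open speak of the compounds shown alone.

Measured compounds:
Compound 1 `[N-]=[N+]=Nc1nccc2c1ncn2[C@H]1C[C@H](O)[C@@H](CO)O1` gives 13% in a functional assay on EL4 cells (Mus musculus) for inhibition, tested at 100 uM; a higher number here means more inhibition at the concentration tested (going by the name of the read-out), a lower number less inhibition.
Compound 2 `CN(C)c1nccc2c1ncn2[C@H]1C[C@H](O)[C@@H](CO)O1` stands at the limit of < 5% in this assay, which is a boundary of the measurement rather than a number.
Compound 3 `CN(C)c1[nH]ccc2ncnc1-2` gives 25% in this assay.

Compound 1 and compound 2 share the same core and differ in one place: azido in place of dimethylamino on an aromatic carbon. Along this change the inhibition moves by a number at least 8 percentage points higher from compound 2 to compound 1 (that floor lies within the scatter). Within the data shown here, this is the one piece of evidence on the step here, since compound 2 sits at the limit of < 5% in this assay, at which 1 of the 3 values shown sits, so only a floor for its size is known.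

Compound 3 carries a different core from compound 2, and the difference between the two cores is not broken down here. Compound 4 `[N-]=[N+]=Nc1[nH]ccc2ncnc1-2` has not been measured yet. It differs from compound 3 by azido in place of dimethylamino on an aromatic carbon. The place around the change is described in the same words as for compound 1 and compound 2, so this is the same change carried over to the core of compound 3.

Resting on the step from compound 2 to compound 1, compound 4 is expected to rise from compound 3 by about a number 8 percentage points higher from compound 3 to compound 4 (within the scatter). Compound 4 is therefore estimated at 33% in this assay, with a plausible range from 20% to 48%.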

Compound 4, a percentage reported as inhibition, at one concentration (the size of the read-out at that concentration, not a potency): < 5%
Compound 4: no number, only a limit; the forecaster's own chance of this, stated with the estimate: 5%; middle value at least 28 percentage points away from the limit.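

In this assay, compound 4 gives < 5%, which is a limit of the measurement and not a number. On this second core, azido in place of dimethylamino on an aromatic carbon gives a number at least 20 percentage points lower from compound 3 to compound 4 (beyond the scatter), so the change that went with a small upward shift on the first core goes the other way here, and the step does not carry over from one core to the other: the same change on two cores in this assay, a number at least 8 percentage points higher (that floor lies within the scatter) from compound 2 to compound 1 and a number at least 20 percentage points lower (beyond the scatter) from compound 3 to compound 4, at least 28 percentage points apart, beyond the scatter of two such steps. This shows that, for these two pairs, the effect of the swap depends on the core it sits on, but it does not show how large either step truly is or what in the cores separates them, and one limit value sits in each pair: the limit of < 5% in this assay, at which 2 of the 4 values shown sit.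

The compounds shown leave open how a primary amine or a methoxy group on that same aromatic carbon would behave on each core, which could tell whether the split between the cores is particular to azido or appears with other groups as well. Also open, as far as these compounds go, is which part of the difference between the two cores matters, as they are linked here only through these two pairs.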